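Replacing the methoxyphenyl in a thiosemicarbazone with chlorophenyl

A few compounds are considered here, and "the series" means these few. Any claim that something is new, unique, unknown or untested is made for them only; others in the source may bear on it.

Compound 1 `COc1ccc(/C=N\NC(=S)NC(C)(C)CCC[C@](C)(O)[C@@H]2CC=C(C)CC2)cc1` is the starting point of this account. In a functional assay on K562 cells (Homo sapiens) for cytotoxicity, read by sulforhodamine B assay (on this read-out lower numbers stand for higher toxicity in this test and higher numbers for lower toxicity in this test), compound 1 gives > 100000 nM, which is a limit of the assay rather than a measured number. Compound 2 `CC1=CC[C@@H]([C@@](C)(O)CCCC(C)(C)NC(=S)N/N=C\c2cccc([N+](=O)[O-])c2)CC1` gives 12600 nM in this assay, so the step of an at least 7.9-fold lower number from compound 1 to compound 2 (0.89 log units; beyond the scatter) is beyond the scatter, though its true size is only bounded on one side because compound 1 sits at the limit of > 100000 nM in this assay, at which 1 of the 2 values shown sits.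

Compound 3 `CC1=CC[C@@H]([C@@](C)(O)CCCC(C)(C)NC(=S)N/N=C\c2ccccc2Cl)CC1` differs from compound 1 by 2-chlorophenyl in place of 4-methoxyphenyl on a carbon with a double bond to nitrogen. Going by the values given here, the only measured step that bears on this change is the one from compound 1 to compound 2, in which a different aryl group also replaced 4-methoxyphenyl and lowered the number; a step in the same direction is therefore expected here, with an uncertain size. The estimated step of an at least 3.3-fold lower number from compound 1 to compound 3 (0.52 log units; beyond the scatter) places compound 3 at an expected 30000 nM in this assay, within a range from 8000 nM to 100000 nM.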

Compound 3, concentration lethal to 50% of the cells: 8500 nM
For compound 3 the middle estimate is 3.5-fold (0.55 log units) above the measured one; the measured number falls inside the stated range.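

In this assay, a second aryl group on a carbon with a double bond to nitrogen now gives a downward step from 4-methoxyphenyl, an at least 11-fold lower number from compound 1 to compound 3 (1.07 log units; beyond the scatter), so the drop seen earlier is not confined to 3-nitrophenyl. This step is bounded on one side only: the limit of > 100000 nM in this assay, at which 1 of the 3 values shown sits. The two replacements, 2-chlorophenyl and 3-nitrophenyl, cannot be told apart in this assay, with a 1.5-fold lower number from compound 2 to compound 3 (0.17 log units; within the scatter), even though they differ in the group they carry and where it sits on the ring.

The compounds shown leave open whether the lower numbers follow the loss of 4-methoxyphenyl or the arrival of these particular groups. An unsubstituted phenyl, a 4-chlorophenyl or a 4-dimethylaminophenyl at this place would help to separate those two readings.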